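This account rests on a few compounds, and the source may have more. Where it says the series, first, only, none or still open, it means among the compounds named here.

Three compounds share a core. Within the data shown here, compound 1 `C=C(Br)C(=O)Nc1cccc(/C=C2\SC(=O)N(Cc3ccc(Cl)cc3)C2=O)c1` gives 940 nM in a functional assay on L1210 cells (Mus musculus) for cytotoxicity, read by cell counting, with a stated time of 2 days (on this read-out higher numbers stand for weaker inhibition and lower numbers for stronger inhibition), and compound 3 `C=C(Br)C(=O)Nc1cccc(/C=C2\SC(=O)N(Cc3ccc(F)cc3)C2=O)c1` gives 680 nM; the only single-change step among them, a 1.4-fold lower number from compound 1 to compound 3 (0.14 log units; within the scatter), lies within the scatter. Compound 2 `C=C(Br)C(=O)Nc1ccc(/C=C2\SC(=O)N(Cc3ccc(C)cc3)C2=O)cc1` gives 3400 nM in this assay, the highest of the three numbers and beyond the scatter from both others. Compound 4 `C=C(Br)C(=O)Nc1ccc(/C=C2\SC(=O)N(C)C2=O)cc1` differs from compound 2 in one place: hydrogen in place of 4-methylphenyl on a saturated chain carbon bound to an amide-type nitrogen in a ring. Among the measured compounds shown here, no measured step touches this place; the one step on record concerns a halogen elsewhere and is within the scatter, so it offers no guide. The outcome is therefore uncertain, with a wide range. Compound 4 is expected to give 5000 nM, between 1500 nM and 20000 nM, in this assay. That estimate means an expected step of a 1.5-fold higher number from compound 2 to compound 4 (0.17 log units; within the scatter).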

Compound 4, half-maximal inhibitory concentration: 190 nM
Compound 4: middle estimate off by 26-fold (1.42 log units), on the high side; measured number below the stated range.
By their numbers in this assay, from the lowest: compound 4; then compounds 3 and 1 (each within the scatter of the next); then compound 2.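

In this assay, replacing 4-methylbenzyl with methyl gives an 18-fold lower number from compound 2 to compound 4 (1.25 log units; beyond the scatter), showing that this place on the shared core can move the number far more than the halogen change elsewhere did. It also shows that the 4-methylphenyl group is not needed for a low number in this series. No measurement shown gives a reason for this step. Still open, as far as these compounds go, is whether a longer chain, a carboxylic acid or an amine at this place would keep the low number. From the compounds shown here alone, it is also open whether methyl would give a similar step on the core of compound 1.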